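The source may report more compounds than this note shows. Statements on the series, on what has been measured and on what is new or still open speak of the compounds shown alone.

Working notes on the series in a functional assay on BGC-823 cells (Homo sapiens) for cytotoxicity, read by MTT assay; on this read-out lower numbers stand for stronger inhibition and higher numbers for weaker inhibition. Compound 2 `Cc1nc(Nc2ccc(Cl)c(Cl)c2)sc1C(=O)/C=C/c1ccccc1` gives 10600 nM in this assay. For the measured compounds named here, compound 3 `Cc1nc(Nc2ccc(Cl)c(Cl)c2)sc1C(=O)/C=C/c1ccc(Cl)cc1` gives 22700 nM in this assay, the highest of the two numbers measured so far. Compound 1 `COc1ccc(/C=C/C(=O)c2sc(Nc3ccc(Cl)cc3)nc2C)cc1` gives only a limit in this assay, > 25000 nM. Going by the values given here, the single measured step, a 2.1-fold higher number from compound 2 to compound 3 (0.33 log units; beyond the scatter), is a modest weakening on the cinnamoyl ring.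

The next compound, compound 4 `COc1ccc(/C=C/C(=O)c2sc(Nc3ccc(Cl)c(Cl)c3)nc2C)cc1`, differs from compound 3 by methoxy in place of chloro on an aromatic carbon. Among the compounds with values here, no measured step in this assay covers an exchange of chloro for methoxy, so the step from compound 3 to compound 4 cannot be read off directly. Compound 1, which also carries the methoxy group, sits at the limit (the limit of > 25000 nM in this assay, at which 1 of the 3 values shown sits), and nothing measured in this assay points toward a stronger inhibition from the methoxy group. The two numbers in hand are both weak, and the expected direction is toward a still higher number or no number at all.

Compound 4 is therefore expected to give about 30000 nM in this assay, with a range from 10000 nM to 100000 nM, and a fair chance that only a limit is recorded. The expected step is a 1.3-fold higher number from compound 3 to compound 4 (0.12 log units; within the scatter).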

Compound 4, half-maximal inhibitory concentration: > 25000 nM
Compound 4: only a limit was reported; the forecaster's own chance of this, stated with the estimate: 50%; the middle value is on the limit's open side.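

In this assay compound 4 gives only a limit, > 25000 nM. Against the chloro analogue the exchange is an at least 1.1-fold higher number from compound 3 to compound 4 (0.04 log units; that floor lies within the scatter), and because that floor lies within the scatter, the data do not separate methoxy from chloro at this place, on the aromatic ring para to a large group. Against the unsubstituted analogue the result is clearer, with an at least 2.3-fold higher number from compound 2 to compound 4 (0.37 log units; beyond the scatter), so in these three compounds both chloro and methoxy at this place give a higher number than hydrogen, and none of the three goes against this.

From the compounds shown here alone, the step between compound 1 and compound 4 cannot be read, so what the added chloro on the other ring does with methoxy in place stays unknown, and the upper end of the range is closed to further ranking: the limit of > 25000 nM in this assay, at which 2 of the 4 values shown sit. Still open is whether any group at this place, such as an amine, a carboxylic acid or a fluoro, would give a number lower than the hydrogen of compound 2.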